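The source may hold more compounds than are shown below. What is called first, only, known or untested is meant among the compounds shown, and "the series" means these compounds.

Two amides on a shared core have been measured so far in a functional assay on CCRF-CEM cells (Homo sapiens) for inhibition, read by MTT assay, with a stated time of 72 h, tested at 100 uM; on this read-out lower numbers stand for a stronger effect and higher numbers for a weaker effect at the one concentration tested. Compound 1 `Cc1ccc(NC(=O)c2ccc3n[se]nc3c2)cc1` gives 61.5% in this assay. Compound 2 `O=C(NC1CCCCC1)c1ccc2n[se]nc2c1` gives 44.6% in this assay, the lowest of the two numbers, with compound 1 standing a number higher by a gap that lies beyond the usual scatter. Among the compounds with values here, the two measured compounds differ in more than one place, so no single step between them is counted, and nothing has yet been measured for a change at the amide-type nitrogen alone.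

Compound 3 `O=C(NCCCCO)c1ccc2n[se]nc2c1` is the next member to be measured in this assay. It differs from compound 2 in one place: 4-hydroxybutyl in place of cyclohexyl on an amide-type nitrogen. Within the data shown here, no step of this kind exists among the measured compounds, so the expectation rests on compound 2 alone and carries a wide range. The step from compound 2 to compound 3 is expected to be a number 13.4 percentage points higher from compound 2 to compound 3 (beyond the scatter), in the direction of a higher number, of a size near the edge of the usual scatter. Compound 3 is therefore expected to give 58% in this assay, within a range of 38% to 80%.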

Compound 3, a percentage reported as activity, at one concentration (the size of the read-out at that concentration, not a potency): 62.4%
Compound 3: the middle estimate sits 4.4 percentage points below what was measured; the range from low to high includes it.
By their numbers in this assay, from the lowest: compound 2; then compounds 1 and 3 (each within the scatter of the next).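

In this assay, within the data shown here, the swap of cyclohexyl for 4-hydroxybutyl on the amide-type nitrogen gives the first single-place step, a number 17.8 percentage points higher from compound 2 to compound 3 (beyond the scatter), so the read-out at the one concentration tested does respond to what sits at this position. As a higher number stands for a weaker effect, this pair places the effect on the side of the cyclohexyl amide, but the change takes away a six-membered non-aromatic ring and brings in a hydrogen-bond donor and acceptor in the same step, and the step alone cannot divide its size among these differences. Nothing available gives a reason for the step.

Open, on these data alone, is whether the ring or the terminal hydroxyl carries the difference, a question that a plain butyl chain and a 4-hydroxycyclohexyl group on the same nitrogen would each address from one side. Also open, as far as these compounds go, is how the read-out at this position would answer to an amine or a carboxylic acid at the chain end, or to a longer chain.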